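The compounds below may be only part of what the source reports. "The series", "measured", "known", "first", "only" and "open" are said of these compounds alone.

Three compounds sharing one core were measured in an assay on HEK293 cells for positive allosteric modulation of metabotropic glutamate receptor 2 (Rattus norvegicus), read by thallium flux, with a stated time of 2.5 min; on this read-out lower numbers stand for smaller maximal responses and higher numbers for larger maximal responses. Compound 1 `Cc1c(OCCCCOCOc2ccc(C(=O)O)cc2)ccc(C(=O)CC2CCCC2)c1O` gives 95.4% in this assay. Compound 2 `Cc1c(OCCCCOc2ccc(C(=O)O)cc2Cl)ccc(C(=O)CC2CCCC2)c1O` gives 82.2%. Compound 3 `COc1ccc(C(=O)O)cc1OCCCCOc1ccc(C(=O)C(C)C)c(O)c1C` gives 66.6%, the lowest of the three numbers, and its distance to both compound 2 and compound 1 lies beyond the usual scatter. Among the compounds with values here, the only step between compounds that differ in a single place, a number 13.2 percentage points lower from compound 1 to compound 2 (beyond the scatter), concerns a different part of the molecule and does not touch the change considered here.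

Compound 4 `COc1ccc(C(=O)O)cc1OCCCCOc1ccc(C(=O)CC2CCCC2)c(O)c1C` differs from compound 3 by cyclopentylmethyl in place of isopropyl on a carbonyl carbon. Within the data shown here, no measured pair differs in this place alone, so no step bears directly on it. Compounds 1 and 2 carry the cyclopentylmethyl group and compound 3 carries isopropyl, but they also differ elsewhere, so their values give only a hint that the cyclopentylmethyl group goes with a larger maximal response.

Compound 4 is therefore expected to reach about 80% in this assay. The expected step of a number 13.4 percentage points higher from compound 3 to compound 4 (beyond the scatter) is modest. Compound 4 is estimated to lie between 62% and 98%.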

Compound 4, largest response reached (reported as percent of maximum), in percent of the reference or control that the assay uses: 91.8%
The estimate for compound 4 lay 11.8 percentage points below the measured number; the measured number falls inside the stated range.
By their numbers in this assay, from the lowest: compound 3; then compounds 2, 4 and 1 (each within the scatter of the next, the first and the last beyond it).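

Placing cyclopentylmethyl instead of isopropyl on the carbonyl carbon, with nothing else altered, gives a number 25.2 percentage points higher from compound 3 to compound 4 (beyond the scatter) in this assay, so the earlier hint now rests on a direct pair. With cyclopentylmethyl in place, changing the group on the oxygen on a saturated carbon gives a number 9.6 percentage points higher from compound 2 to compound 4 (within the scatter) and a number 3.6 percentage points lower from compound 1 to compound 4 (within the scatter), so neither of these steps separates compound 4 from its partner. Nothing measured here explains why the group on the carbonyl carbon changes the maximal response.

On these data alone, whether a cyclohexylmethyl group or a longer open chain on the carbonyl carbon would give a similar response remains open. It is also open whether the step holds with 4-carboxy-2-chlorophenyl on the oxygen, since only the cyclopentylmethyl compound with that group is shown.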